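A swap on the amide-type nitrogen of compound 3

This account rests on a few compounds, and the source may have more. Where it says the series, first, only, none or still open, it means among the compounds named here.

Measured in a functional assay on MDA-MB-436 cells (Homo sapiens) for antiproliferative activity, read by MTT assay, with a stated time of 48 h; a lower number here means a stronger inhibitor, a higher number a weaker inhibitor:
compound 1 `C=CS(=O)(=O)N1CCN(c2nc(OC[C@H]3CCCN3C)nc3sc(-c4ccc(N5CCN(C)CC5)cc4)cc23)[C@@H](C)C1` gives 1920 nM
compound 2 `CCS(=O)(=O)N1CCN(c2ncnc3sc(-c4ccc(N5CCN(C)CC5)cc4)cc23)CC1` gives 10600 nM
compound 3 `CN1CCN(c2ccc(-c3cc4c(N5CCN(C(=O)Nc6ccc(OC(F)(F)F)cc6)CC5)ncnc4s3)cc2)CC1` gives 6250 nM

Compound 3 at 6250 nM and compound 2 at 10600 nM lie within the usual scatter of each other, so no order can be drawn between them. Compound 1 at 1920 nM has a lower number than compound 3, and that gap lies beyond the scatter. These three compounds differ in more than one place, so none of the gaps can be tied to a single structural change.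

The next compound is compound 4 `CN1CCN(c2ccc(-c3cc4c(N5CCN(C(=O)Nc6cc(C(F)(F)F)ccc6F)CC5)ncnc4s3)cc2)CC1`, which differs from compound 3 in one place only. The change is 2-fluoro-5-(trifluoromethyl)phenyl in place of 4-(trifluoromethoxy)phenyl on an amide-type nitrogen, with 2-fluoro-5-(trifluoromethyl)phenyl in place of 4-(trifluoromethoxy)phenyl on an amide-type nitrogen. Going by the values given here, the two groups match in heavy-atom count, but no measured pair shows what a swap of this kind does in this assay. For that reason, no step beyond the scatter is expected, and the estimate stays anchored on compound 3 at 6250 nM. The estimated change is small, a 1.3-fold lower number from compound 3 to compound 4 (0.10 log units; within the scatter), and stays within the scatter. Compound 4 is expected at 5000 nM, with an estimated range from 2000 nM to 12500 nM.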

Compound 4, half-maximal inhibitory concentration: 8840 nM
The estimate for compound 4 lay 1.8-fold (0.25 log units) below the measured number, within the range that was stated.
By their numbers in this assay, from the lowest: compound 1; then compounds 3, 4 and 2 (each within the scatter of the next).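

In this assay, going by these compounds alone, putting 2-fluoro-5-(trifluoromethyl)phenyl in place of 4-(trifluoromethoxy)phenyl on the amide-type nitrogen gives a 1.4-fold higher number from compound 3 to compound 4 (0.15 log units; within the scatter), the first comparison here in which only one place differs. This read-out therefore does not separate these two groups, even though the entering group has four fluorine atoms and no oxygen, while the leaving group has three fluorine atoms and one oxygen, and their hydrogen-bond acceptor counts also differ. No measurement shown here explains this result.

As far as these compounds go, both groups at this position are fluorine-bearing phenyl rings of equal heavy-atom count, so it remains open whether an unsubstituted phenyl, a phenyl carrying an amine or a carboxylic acid, or a simple alkyl chain would give a number beyond the scatter of compound 3. From the compounds shown here alone, it also remains open what this position can do on the core of compound 1, which differs from compound 3 in more than one place.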